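Replacing 3-nitrophenyl in compound 1

A few compounds are considered here, and "the series" means these few. Any claim that something is new, unique, unknown or untested is made for them only; others in the source may bear on it.

Compound 1 (`COc1ccc(Oc2ccccc2-c2ccsc2S(=O)(=O)N2CCN(C(=O)Nc3cccc([N+](=O)[O-])c3)CC2)cc1OC`) gives > 50000 nM in a functional assay on RS4-11 cells (Homo sapiens) for inhibition, read by CCK-8 assay, with a stated time of 48 h (a higher number here means a weaker inhibitor, a lower number a stronger inhibitor), and this value is a limit, not a number. Compound 2 (`Cc1cc(C)cc(NC(=O)NCCNS(=O)(=O)c2ccc(-c3ccccc3OCc3ccccc3)s2)c1`) gives > 50000 nM in this assay and this too is a limit. Within the data shown here, compound 1 thus stands at the limit of > 50000 nM in this assay, at which 2 of the 2 values shown sit, and offers no measured number to step from. Compound 3 (`COc1ccc(Oc2ccccc2-c2ccsc2S(=O)(=O)N2CCN(C(=O)Nc3ccc(F)cc3)CC2)cc1OC`) has 4-fluorophenyl in place of 3-nitrophenyl on an amide-type nitrogen. Among the measured compounds shown here, no measured step covers this change, so no step beyond the scatter is expected in this assay for it. The estimated step is an at least 1.1-fold lower number from compound 1 to compound 3 (0.04 log units; that floor lies within the scatter) and carries that expectation. In this assay compound 3 is estimated at 45000 nM with a range from 15000 nM to 70000 nM as the expected span.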

Compound 3, half-maximal inhibitory concentration: 14900 nM
Compound 3: middle estimate off by 3.0-fold (0.48 log units), on the high side, outside the stated range (below it).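

On the amide-type nitrogen, 4-fluorophenyl in place of 3-nitrophenyl gives an at least 3.3-fold lower number from compound 1 to compound 3 (0.52 log units; beyond the scatter) in this assay, so this position can move the read-out. Compound 3 is the first compound shown with a measured number, 14900 nM. Compound 1 remains a limit, so the step is only a floor: the limit of > 50000 nM in this assay, at which 2 of the 3 values shown sit.

The compounds shown do not separate the loss of 3-nitrophenyl from the arrival of 4-fluorophenyl. As far as these compounds go, how plain phenyl or 4-chlorophenyl would read on this nitrogen remains open.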